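A few compounds are considered here, and "the series" means these few. Any claim that something is new, unique, unknown or untested is made for them only; others in the source may bear on it.

Of the compounds shown here, three have been measured in an ADME assay on L02 cells (Homo sapiens) for cytotoxicity, read by MTT assay, with a stated time of 24 h (on this read-out lower numbers stand for stronger inhibition and higher numbers for weaker inhibition), and a fourth still awaits its number. Compound 1 `COc1cc(/C=C2\CN(C)C/C(=C\c3ccccc3F)C2=O)cc(OC)c1OC` gives 12100 nM in this assay. Compound 3 `COc1cc(/C=C2\CN(C)C/C(=C\c3ccc(F)cc3)C2=O)cc(OC)c1OC` differs from compound 1 in one place, (4-fluorophenyl in place of 2-fluorophenyl on a double-bonded chain carbon bound to a double-bonded ring carbon), and in this assay compound 3 gives 10700 nM, a step of a 1.1-fold lower number from compound 1 to compound 3 (0.05 log units; within the scatter). Compound 2 `CN1C/C(=C\c2cccc([N+](=O)[O-])c2)C(=O)/C(=C/c2ccccc2F)C1` is built on a different core; how its core differs from that of compound 1 is not broken down here. In this assay compound 2 gives 13500 nM, a number that sits close to those of compound 1 and compound 3. Compound 4 `CN1C/C(=C\c2ccc(F)cc2)C(=O)/C(=C/c2cccc([N+](=O)[O-])c2)C1` has not yet been measured. It differs from compound 2 in one place, (4-fluorophenyl in place of 2-fluorophenyl on a double-bonded chain carbon bound to a double-bonded ring carbon), the same change that turns compound 1 into compound 3. Because the earlier step of a 1.1-fold lower number from compound 1 to compound 3 (0.05 log units; within the scatter) stayed inside the usual scatter, a step of similar size is expected from compound 2 to compound 4, roughly a 1.1-fold lower number from compound 2 to compound 4 (0.05 log units; within the scatter). Compound 4 is therefore estimated at 12000 nM, with the number expected to fall between 6000 nM and 24000 nM.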

Compound 4, half-maximal inhibitory concentration: 17600 nM
Estimate against measurement, compound 4: 1.5-fold (0.17 log units) below; measured number inside the range.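

In this assay, putting 4-fluorophenyl in place of 2-fluorophenyl on the core of compound 2 gives a 1.3-fold higher number from compound 2 to compound 4 (0.12 log units; within the scatter). Set beside the same change on the core of compound 1, this step cannot be told apart from the earlier one: the same change on two cores in this assay, a 1.1-fold lower number (0.05 log units; within the scatter) from compound 1 to compound 3 and a 1.3-fold higher number (0.12 log units; within the scatter) from compound 2 to compound 4, 1.5-fold (0.17 log units) apart, within the scatter of two such steps. On these two cores, then, the change carries over in the plain sense that neither step rises above the normal noise of the measurement, but the two pairs show no reliable direction of change and give no rule for other cores in the series.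

The compounds shown leave open whether a larger step would appear if the fluorine on the phenyl ring gave way to a different group, such as a chlorine, an amine or a carboxylic acid. They also leave open whether the same change would behave alike on a core with a longer chain, such as ethyl, in place of the methyl on the ring nitrogen.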